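The source may report more compounds than this note shows. Statements on the series, on what has been measured and on what is new or still open speak of the compounds shown alone.

In a functional assay on LOX IMVI cells (Homo sapiens) for cytotoxicity, read by MTT assay, with a stated time of 24 h (a higher number here means a weaker inhibitor, a lower number a stronger inhibitor), two related sulfonamides have been measured so far. Compound 2, `O=S(=O)(NCCCNc1nccc(-c2[nH]c(-c3ccccc3)nc2-c2ccc(Cl)c(O)c2)n1)c1ccc(Br)cc1`, gives 15500 nM, the higher of the two numbers, and the gap to compound 1, `COc1cc(-c2nc(-c3ccccc3)[nH]c2-c2ccnc(NCCCNS(=O)(=O)c3ccc(F)cc3)n2)ccc1Cl`, at 4530 nM, lies beyond the usual scatter. Compound 3, `O=S(=O)(NCCCNc1nccc(-c2[nH]c(-c3ccccc3)nc2-c2ccc(Cl)c(O)c2)n1)c1ccc(F)cc1`, departs from compound 2 at a single place: fluoro in place of bromo on an aromatic carbon. This is fluoro in place of bromo on an aromatic carbon, turning 4-bromophenyl into 4-fluorophenyl. Going by the values given here, no measured pair isolates this change. Among the compounds with values here, the only guide is compound 1, which carries the same 4-fluorophenyl group at 4530 nM but also differs from compound 3 elsewhere. A small shift toward a lower number is therefore expected, probably within the scatter. The expected change is a 1.6-fold lower number from compound 2 to compound 3 (0.21 log units; within the scatter). For compound 3, the estimated value is 9500 nM, with an expected range from 4500 nM to 20000 nM.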

Compound 3, half-maximal inhibitory concentration: 2300 nM
Beside the measured number, compound 3's estimate is 4.1-fold (0.62 log units) above it; measured number below the stated range.
By their numbers in this assay, from the lowest: compounds 3 and 1 (each within the scatter of the next); then compound 2.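

In this assay, going by these compounds alone, the swap of 4-bromophenyl for 4-fluorophenyl gives the first reading at this position, a 6.7-fold lower number from compound 2 to compound 3 (0.83 log units; beyond the scatter), so the halogen on this ring clearly counts. The second comparison, hydrogen in place of methyl on an oxygen on an aromatic ring, gives a 2.0-fold lower number from compound 1 to compound 3 (0.29 log units; within the scatter), so compound 1 and compound 3 cannot be told apart here. Nothing measured here explains the size of the halogen step.

The compounds shown leave open how chloro, methyl or an amine would read at this place on the ring, and whether the fluoro-for-bromo step keeps its size with the methoxy group of compound 1 on the core. On these data alone, a longer chain in place of the present linker also remains open.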